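This account rests on a few compounds, and the source may have more. Where it says the series, first, only, none or still open, it means among the compounds named here.

Compound 1 `CN(Cc1cccc(F)c1)C(=O)c1cnc(-c2ccc(S(C)(=O)=O)c([N+](=O)[O-])c2)s1`: 3200 nM
Compound 2 `CC1(C)CC2CC(C)(CN2C(=O)c2sc(-c3ccc(S(C)(=O)=O)c([N+](=O)[O-])c3)nc2C(F)(F)F)C1`: 430 nM

Of the compounds shown here, two have been measured in a functional assay for antagonist activity at thyroid hormone receptor alpha (Homo sapiens), read by fluorescence polarization; on this read-out lower numbers stand for stronger inhibition and higher numbers for weaker inhibition. Compound 2 gives 430 nM, the lowest of the two numbers; compound 1 gives 3200 nM, a gap that lies beyond the scatter of repeated measurements. Compound 3 `CN(Cc1cccc(F)c1)C(=O)c1sc(-c2ccc(S(C)(=O)=O)c([N+](=O)[O-])c2)nc1C(F)(F)F` has not yet been measured in this assay. It differs from compound 2 in one place: a group of 10 heavy atoms (8 carbon, 1 nitrogen, 1 fluorine; one six-membered aromatic ring of carbon only) in place of a group of 11 heavy atoms (10 carbon, 1 nitrogen; one five-membered non-aromatic ring with 1 hetero atom, one six-membered non-aromatic ring of carbon only), on a carbonyl carbon. The (3-fluorobenzyl)(methyl)amino group that enters is the same group carried by compound 1, so compound 3 joins that amine to the core of compound 2. Going by the values given here, no direct step between measured compounds covers this change, so the expected size of the step rests on the two values. In this assay the step from compound 2 to compound 3 is expected to be a 3.5-fold higher number from compound 2 to compound 3 (0.54 log units; beyond the scatter), toward weaker inhibition. Compound 3 is therefore estimated at 1500 nM, with a range from 500 nM to 5000 nM.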

Compound 3, half-maximal inhibitory concentration: 1000 nM
Compound 3: the middle estimate sits 1.5-fold (0.18 log units) above what was measured; the range from low to high includes it.
By their numbers in this assay, from the lowest: compound 2; then compound 3; then compound 1.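

In this assay, trifluoromethyl in place of hydrogen on an aromatic carbon gives a 3.2-fold lower number from compound 1 to compound 3 (0.51 log units; beyond the scatter) with the (3-fluorobenzyl)(methyl)amino group held constant, so this single change goes with stronger inhibition. With the trifluoromethyl group held constant, placing (3-fluorobenzyl)(methyl)amino on the carbonyl carbon in place of the amine with two non-aromatic rings gives a 2.3-fold higher number from compound 2 to compound 3 (0.37 log units; beyond the scatter) and weaker inhibition, so the choice of amine also matters in this series. Nothing available explains either step.

From the compounds shown here alone, whether a methyl group or a chlorine atom on that aromatic carbon would match trifluoromethyl remains open. So does whether a simple amine such as piperidine on the carbonyl carbon would give inhibition closer to that of compound 2 or compound 3.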